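A few compounds are considered here, and "the series" means these few. Any claim that something is new, unique, unknown or untested is made for them only; others in the source may bear on it.

Compound 3 `CC(C)(C)n1ncc(OCc2nnc(-c3cccc(F)c3)o2)c(Cl)c1=O` is the only one of the three measured compounds to give a number in a functional assay on the whole organism for inhibition, with Mythimna separata as the target, with a stated time of 5 days (a lower number here means that less compound is needed, a higher number that more compound is needed for the effect), where compound 3 reaches 7100 nM. Compound 1 `COc1c(F)c(F)cc(-c2nnc(COc3cnn(C(C)(C)C)c(=O)c3Cl)o2)c1F` sits at the limit of the assay, > 299000 nM, rather than at a number. Compound 2 `Cc1nnc(COc2cnn(C(C)(C)C)c(=O)c2Cl)o1` likewise sits at the limit, > 299000 nM. The single measured step joining two of these compounds is an at least 42-fold lower number from compound 2 to compound 3 (1.62 log units; beyond the scatter), a step that rests on the limit of > 299000 nM in this assay, at which 2 of the 3 values shown sit, and is therefore known only as a bound. Compound 4 `CC(C)(C)n1ncc(OCc2nnc(-c3cc(F)c(F)cc3F)o2)c(Cl)c1=O` differs from compound 3 by 2,4,5-trifluorophenyl in place of 3-fluorophenyl on an aromatic carbon. No measured step bears directly on adding fluorines to a phenyl that is already present; compound 1, which carries a more heavily substituted phenyl on the same core, gave only the limit while compound 3 gave a number, but the two are not joined by a listed step. Since the phenyl ring itself is retained, compound 4 is expected to stay measurable, though with some loss, at an estimated 30000 nM, within 5000 nM to 299000 nM. This expectation amounts to a 4.2-fold higher number from compound 3 to compound 4 (0.63 log units; beyond the scatter).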

Compound 4, half-maximal effective concentration: 75700 nM
Compound 4: the middle estimate sits 2.5-fold (0.40 log units) below what was measured, and the stated range covers the measured number.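

The step to 2,4,5-trifluorophenyl gives an 11-fold higher number from compound 3 to compound 4 (1.03 log units; beyond the scatter) in this assay and shows that, at this position, keeping a phenyl does not by itself hold the number: which fluorines the ring carries matters. The same group still improves on methyl, with an at least 3.9-fold lower number from compound 2 to compound 4 (0.59 log units; beyond the scatter) as the step, and taking the methoxy off the phenyl, with hydrogen in its place, gives an at least 3.9-fold lower number from compound 1 to compound 4 (0.59 log units; beyond the scatter) as a second step. Both of these steps start from a limit and are known only as bounds: the limit of > 299000 nM in this assay, at which 2 of the 4 values shown sit.

From the compounds shown here alone, whether the loss follows the number of fluorines or their places on the ring stays open. So does how a phenyl without fluorine, or one bearing a nitrile or an amine, would read in this assay at this position.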